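The source may report more compounds than this note shows. Statements on the series, on what has been measured and on what is new or still open speak of the compounds shown alone.

Of the compounds shown here, three built on a shared core have so far been tested in an assay on cells for inhibition of cytochrome P450 11B2, mitochondrial (Homo sapiens), read by HPLC, with a stated time of 90 min; on this read-out higher numbers stand for weaker inhibition and lower numbers for stronger inhibition. Compound 1 `Fc1ccc2nc(-c3cnco3)n(C3CC3)c2c1` gives only a limit, > 10000 nM (the limit of > 10000 nM in this assay, at which 1 of the 3 values shown sits). Within the data shown here, compound 2 `Fc1ccc2nc(-c3cncnc3)n(C3CC3)c2c1` gives 40 nM, and the single measured step, an at least 250-fold lower number from compound 1 to compound 2 (2.39 log units; beyond the scatter), is the largest event in the set. Among the measured compounds shown here, compound 3 `N#Cc1ncncc1-c1nc2cc(F)c(F)cc2n1C1CC1` gives 13 nM, the lowest of the two numbers, with compound 2 standing higher by a gap beyond the scatter; the two compounds differ in more than one place, so no single step links them.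

Compound 4 `Fc1cc2nc(-c3cncnc3C(F)F)n(C3CC3)c2cc1F` has not yet been measured. It differs from compound 3 by difluoromethyl in place of cyano on an aromatic carbon. For the measured compounds named here, the one measured step concerns the exchange of the whole heteroaryl ring and says nothing about a substituent on that ring, so it does not bear on this change. With compounds 2 and 3 both at low numbers, a modest step is expected here. This change is expected to produce a 1.9-fold higher number from compound 3 to compound 4 (0.28 log units; within the scatter). Compound 4 is estimated at 25 nM, with a range from 8 nM to 80 nM.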

Compound 4, half-maximal inhibitory concentration: 18 nM
Estimate against measurement, compound 4: 1.4-fold (0.14 log units) above; the measured number falls inside the stated range.
By their numbers in this assay, from the lowest: compounds 3 and 4 (each within the scatter of the next); then compound 2. At a limit, above all of these: compound 1.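

In this assay the exchange at this position gives a 1.4-fold higher number from compound 3 to compound 4 (0.14 log units; within the scatter), so the read-out does not separate the two groups on this aromatic carbon, next to the ring nitrogen and ortho to a large group. Among these compounds, this is the first measured change of a substituent on the six-membered ring with 2 nitrogen, whereas the earlier step exchanged the whole ring. Cyano, with its triple bond and hydrogen-bond acceptor, gives way to difluoromethyl, which has neither, and no change beyond the scatter follows, though nothing measured here offers a reason for this.

As far as these compounds go, what an amine, a carboxylic acid or a longer chain would do at this position remains open. So does the separate share of the substituent and of the added fluorine in the gap between compound 2 and compound 3, which differ in more than one place.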